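From compound 2 to compound 3: one group exchanged

This account rests on a few compounds, and the source may have more. Where it says the series, first, only, none or still open, it means among the compounds named here.

In a functional assay on RS4-11 cells (Homo sapiens) for inhibition, read by CCK-8 assay, with a stated time of 48 h (on this read-out lower numbers stand for stronger inhibition and higher numbers for weaker inhibition), compound 2 (`O=[N+]([O-])c1cccc(NC(=S)NCCNS(=O)(=O)c2ccc(-c3ccccc3OCc3ccccc3)s2)c1`) gives 11600 nM, the higher of the two numbers available. Compound 1 (`Cc1cc(C)cc(NC(=O)NCCNS(=O)(=O)c2ccc(-c3ccccc3Oc3ccc([N+](=O)[O-])c([N+](=O)[O-])c3)s2)c1`) gives 3600 nM, a gap beyond the scatter. Compound 3 (`Cc1cc(C)cc(NC(=O)NCCNS(=O)(=O)c2ccc(-c3ccccc3OCc3ccccc3)s2)c1`) keeps the rest of compound 2 and changes one group: a group of 11 heavy atoms (9 carbon, 1 nitrogen, 1 oxygen; one six-membered aromatic ring of carbon only) in place of a group of 12 heavy atoms (7 carbon, 2 nitrogen, 2 oxygen, 1 sulfur; one six-membered aromatic ring of carbon only), on an amine nitrogen. Within the data shown here, no measured pair shows this exchange alone. Compound 1 also carries the (3,5-dimethylphenyl)carbamoyl and reads 3600 nM, so a modest fall in the number is expected. The estimated change is a 1.9-fold lower number from compound 2 to compound 3 (0.29 log units; within the scatter). Compound 3 is expected near 6000 nM, with an estimated range from 2500 nM to 14000 nM.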

Compound 3, half-maximal inhibitory concentration: > 50000 nM
Compound 3 ended at the assay's limit; the forecaster's own chance of this, stated with the estimate: 8%; at least 8.3-fold (0.92 log units) between middle value and limit.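

Compound 3 gives only a limit, not a number, in this assay and so sits at the edge of the read-out: the limit of > 50000 nM in this assay, at which 1 of the 3 values shown sits. On the amine nitrogen, the (3,5-dimethylphenyl)carbamoyl group in place of the group of compound 2 gives an at least 4.3-fold higher number from compound 2 to compound 3 (0.63 log units; beyond the scatter) and this change does not lower the number as compound 1 had suggested. With that same group in place, the group on the oxygen matters strongly, as benzyl in place of 3,4-dinitrophenyl gives an at least 13-fold higher number from compound 1 to compound 3 (1.14 log units; beyond the scatter) and no number can be read. Going by these compounds, how far past the limit compound 3 lies stays open, as does whether an amine in place of the benzyl would bring a readable number back.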